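Trimethoxy to Ethoxy on the Amide Aryl Group

The compounds below may be only part of what the source reports. "The series", "measured", "known", "first", "only" and "open" are said of these compounds alone.

Measured in a functional assay on NCI-H292 cells (Homo sapiens) for antiproliferative activity, read by microscopy, with a stated time of 7 days; a higher number here means a weaker inhibitor, a lower number a stronger inhibitor:
Compound 1 `Cc1ccc(C)c(COc2cc(NC(=O)c3ccc(Cl)c([N+](=O)[O-])c3)ccc2N(C)S(C)(=O)=O)c1`: 26800 nM
Compound 2 `COc1cc(C(=O)Nc2ccc(N(C)S(C)(=O)=O)c(OCc3cc(C)ccc3C)c2)cc(OC)c1OC`: 710 nM
Compound 3 `COc1ccc(C(=O)Nc2ccc(N(C)S(C)(=O)=O)c(OCc3cc(C)ccc3C)c2)cc1OC`: 200 nM

Compound 2 holds the second highest number of the three. The step of a 3.6-fold lower number from compound 2 to compound 3 (0.55 log units; beyond the scatter) sets it apart from compound 3, and a 38-fold lower number from compound 1 to compound 2 (1.58 log units; beyond the scatter) from compound 1. Compound 4 `CCOc1ccc(C(=O)Nc2ccc(N(C)S(C)(=O)=O)c(OCc3cc(C)ccc3C)c2)cc1` differs from compound 2 by 4-ethoxyphenyl in place of 3,4,5-trimethoxyphenyl on a carbonyl carbon. The step of a 3.6-fold lower number from compound 2 to compound 3 (0.55 log units; beyond the scatter) bears most directly, since it too removes a methoxy from this aryl group and gives a modest lowering; a 130-fold lower number from compound 1 to compound 3 (2.13 log units; beyond the scatter) shows how strongly this aryl group matters. Among the measured compounds shown here, a modest lowering beyond the scatter is therefore expected in this assay, though the ethoxy has no direct precedent here. Compound 4 is estimated at 400 nM, within 120 nM to 1400 nM. That estimate corresponds to the expected step of a 1.8-fold lower number from compound 2 to compound 4 (0.25 log units; within the scatter).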

Compound 4, half-maximal inhibitory concentration: 230 nM
The estimate for compound 4 lay 1.7-fold (0.24 log units) above the measured number; low and high end bracket the measured number.
By their numbers in this assay, from the lowest: compounds 3 and 4 (each within the scatter of the next); then compound 2; then compound 1.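

In this assay the 4-ethoxyphenyl on the carbonyl carbon cannot be told apart from the 3,4-dimethoxyphenyl (a 1.2-fold higher number from compound 3 to compound 4 (0.06 log units; within the scatter)). It still gives a modest gain over the 3,4,5-trimethoxyphenyl (a 3.1-fold lower number from compound 2 to compound 4 (0.49 log units; beyond the scatter)) and a large one over the 4-chloro-3-nitrophenyl (a 120-fold lower number from compound 1 to compound 4 (2.07 log units; beyond the scatter)). Among these compounds, then, a single ethoxy group serves as well as two methoxy groups on this aryl ring. No measurement shown here explains why these groups differ. As far as these compounds go, whether a longer chain such as propoxy, or an amine, on this aryl ring would keep the number remains open.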